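Trimming the amine side chain of an antiproliferative quinoline amide

The compounds below may be only part of what the source reports. "The series", "measured", "known", "first", "only" and "open" are said of these compounds alone.

Compounds measured so far:
compound 1, `CCN1CCN(c2cc(C)c3cc(NC(=O)c4cccc(Cl)c4)ccc3n2)CC1`, 17800 nM
compound 2, `CCN(CC)CCNc1cc(C)c2cc(NC(=O)c3ccc(Cl)c(Cl)c3)ccc2n1`, 3710 nM
compound 3, `CCN1CCN(c2cc(C)c3cc(NC(=O)c4ccccc4C)ccc3n2)CC1`, 29200 nM

These three share a core carrying an amide on one side and an amine on the other, and were tested in a functional assay on SK-BR-3 cells (Homo sapiens) for antiproliferative activity, read by MTT assay, with a stated time of 72 h; on this read-out higher numbers stand for weaker inhibition and lower numbers for stronger inhibition. Compound 2 gives the lowest number of the three, and its gaps to compound 1 and to compound 3 are both beyond the scatter, so it is the strongest inhibitor here. Within the data shown here, the one measured single-point step, a 1.6-fold higher number from compound 1 to compound 3 (0.21 log units; within the scatter), concerns the amide side and lies within the scatter.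

Compound 4, `Cc1cc(N(C)C)nc2ccc(NC(=O)c3ccc(Cl)c(Cl)c3)cc12`, alters compound 2 on the amine side instead: dimethylamino in place of (2-(diethylamino)ethyl)amino on an aromatic carbon. Among the measured compounds shown here, no measured step touches this side of the molecule, so the data give no direct guide to the size or direction of the change. The step from compound 2 to compound 4 is therefore expected to be modest and uncertain, a 1.9-fold higher number from compound 2 to compound 4 (0.28 log units; within the scatter). Compound 4 is estimated at 7000 nM, within a range from 2000 nM to 25000 nM.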

Compound 4, half-maximal inhibitory concentration: > 50000 nM
Compound 4: a limit, no number (the forecaster's own chance of this, stated with the estimate: 5%); at least 7.1-fold (0.85 log units) between middle value and limit.
By their numbers in this assay, from the lowest: compound 2; then compounds 1 and 3 (each within the scatter of the next). At a limit, above all of these: compound 4.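

In this assay, the amine side of the shared core proves far more sensitive than the earlier data could show, as dimethylamino in place of (2-(diethylamino)ethyl)amino gives an at least 13-fold higher number from compound 2 to compound 4 (1.12 log units; beyond the scatter). The entry for compound 4 is a limit of the assay and not a number: the limit of > 50000 nM in this assay, at which 1 of the 4 values shown sits.
Among these compounds, the true size of this step therefore stays unknown, but it clearly exceeds the only earlier step, which was on the amide side: a 1.6-fold higher number from compound 1 to compound 3 (0.21 log units; within the scatter).

Compound 4 gives up both the hydrogen-bond donor and the long chain with its terminal diethylamino group in a single change, so the compounds shown cannot separate these two differences. Methylamino would keep the donor on a short group, whereas (2-(dimethylamino)ethyl)amino would keep the chain with smaller groups on its terminal amine, and either could help tell the two apart.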